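Replacing 1,3-oxazol-2-yl with 5-fluoropyridin-2-yl in compound 4

The compounds below may be only part of what the source reports. "The series", "measured", "known", "first", "only" and "open" are said of these compounds alone.

Measured in a toxicity assay on HepG2 2.2.15 cells (Homo sapiens) for cytotoxicity, read by CellTiter-Glo; on this read-out higher numbers stand for lower toxicity in this test and lower numbers for higher toxicity in this test:
Compound 1 `O=C1CC(c2cnc(C(F)(F)F)s2)CN1c1cnn2c1CN(C(=O)Nc1cc(F)c(F)c(F)c1)C(C1CC1)C2`: 38500 nM
Compound 2 `O=C1CC(Oc2ncc(F)cn2)CN1c1cnn2c1CN(C(=O)Nc1cc(F)c(F)c(F)c1)C(C1CC1)C2`: 96200 nM
Compound 3 `O=C1CC(c2ncco2)CN1c1cnn2c1CN(C(=O)Nc1cc(F)c(F)c(F)c1)C(C1CC1)C2`: > 200000 nM (a limit of the assay, not a number)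

Compound 3 gives only a limit in this assay, > 200000 nM. Even so, it stands highest of the three, as two steps show: an at least 5.1-fold higher number from compound 1 to compound 3 (0.71 log units; beyond the scatter) and an at least 2.0-fold higher number from compound 2 to compound 3 (0.31 log units; beyond the scatter). The remaining step is a 2.5-fold higher number from compound 1 to compound 2 (0.40 log units; beyond the scatter).

Compound 4 `O=C1CC(c2ccc(F)cn2)CN1c1cnn2c1CN(C(=O)Nc1cc(F)c(F)c(F)c1)C(C1CC1)C2` differs from compound 3 by one change: 5-fluoropyridin-2-yl in place of 1,3-oxazol-2-yl on a saturated ring carbon. All three measured steps changed this same place, and each was modest or at least modest. Of the other two groups, compound 1 gave 38500 nM and compound 2 gave 96200 nM. On that basis, a modest step to a lower number is expected, though compound 4 could still reach the limit. The expected step is an at least 2.3-fold lower number from compound 3 to compound 4 (0.37 log units; beyond the scatter). For compound 4 the estimated value is 85000 nM, with an expected range of 35000 nM to 190000 nM.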

Compound 4, half-maximal cytotoxic concentration: 38500 nM
Compound 4: the middle estimate sits 2.2-fold (0.34 log units) above what was measured, within the range that was stated.
By their numbers in this assay, from the lowest: compounds 1 and 4 (each within the scatter of the next); then compound 2. At a limit, above all of these: compound 3.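

In this assay, 5-fluoropyridin-2-yl on this saturated ring carbon gives no change at the digits printed from compound 1 to compound 4 (within the scatter), so the low end of the series is not confined to the 2-(trifluoromethyl)-1,3-thiazol-5-yl group. Set against the other two groups, the same change gives a 2.5-fold lower number from compound 2 to compound 4 (0.40 log units; beyond the scatter) and an at least 5.1-fold lower number from compound 3 to compound 4 (0.71 log units; beyond the scatter), which leaves 1,3-oxazol-2-yl apart from both six-membered-ring groups shown. Compound 3 stands at a limit, not a number, so its step can be read only as a bound: the limit of > 200000 nM in this assay, at which 1 of the 4 values shown sits.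

The compounds shown leave open whether plain pyridin-2-yl, without the fluorine, would read with compound 4 or nearer compound 3. They also leave open what an amine or a carboxylic acid on this carbon would do to the number.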